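A few compounds are considered here, and "the series" means these few. Any claim that something is new, unique, unknown or untested is made for them only; others in the source may bear on it.

Working notes on the series. In a functional assay on SW480 cells (Homo sapiens) for cytotoxicity, read by MTT assay, with a stated time of 24 h (a lower number here means a stronger inhibitor, a higher number a weaker inhibitor), compound 1 `C=CC1=C(C(=O)NCc2ccccc2)C(c2ccc(OC)c(OC)c2)OC1` reaches only the limit of the assay, > 100000 nM. Compound 2 `C=CC1=C(C(=O)NCC(C)C)C(c2ccc(F)cc2)OC1` likewise gives only a limit, > 100000 nM. Compound 3 `C=CC1=C(C(=O)Nc2ccccc2)C(c2ccc(OC)cc2)OC1` also stops at a limit, > 100000 nM. Among the measured compounds shown here, all three values sit at the same boundary, (the limit of > 100000 nM in this assay, at which 3 of the 3 values shown sit), so no numbered potency and no measured step is available for any pair in this assay. Compound 4 `C=CC1=C(C(=O)NCc2ccc(Cl)cc2)C(c2ccc(OC)c(OC)c2)OC1` has not been run yet. It differs from compound 1 by chloro in place of hydrogen on an aromatic carbon. With every measured member at the limit, the step is expected to be none beyond the scatter: a number no higher from compound 1 to compound 4 (the limit leaves the size open). Compound 4 is therefore expected to return 100000 nM, within 40000 nM to 300000 nM, most likely again as a limit.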

Compound 4, half-maximal inhibitory concentration: > 100000 nM
Compound 4 gave a limit, no number (the forecaster's own chance of this, stated with the estimate: 85%); the middle value lies on the limit itself.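

No step can be read between compound 1 and compound 4 in this assay, as both stop at a limit: the limit of > 100000 nM in this assay, at which 4 of the 4 values shown sit.
The compounds shown leave open what chloro in place of hydrogen does to potency, and whether any compound in the series gives a numbered value in this assay.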